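The source may hold more compounds than are shown below. What is called first, only, known or untested is meant among the compounds shown, and "the series" means these compounds.

Compound 1 `CN(C)Cc1ccc2nc(NC(=O)N/N=C/c3cn(Cc4ccccc4Cl)c4ccccc34)sc2c1` is the shared core carrying a dimethylaminomethyl arm and a 2-chlorobenzyl group. In a functional assay on MDA-MB-231 cells (Homo sapiens) for cytotoxicity, read by MTT assay, with a stated time of 72 h (a lower number here means a stronger inhibitor, a higher number a weaker inhibitor), compound 1 gives 1180 nM, the lowest of the three numbers, with compound 3 `CC1CCN(Cc2ccc3nc(NC(=O)N/N=C/c4c[nH]c5ccccc45)sc3c2)CC1` giving 2460 nM and compound 2 `CC1CCN(Cc2ccc3nc(NC(=O)N/N=C/c4cn(Cc5ccc(Cl)cc5Cl)c5ccccc45)sc3c2)CC1` giving 3140 nM. Compound 4 `CN(C)Cc1ccc2nc(NC(=O)N/N=C/c3cn(Cc4ccccc4)c4ccccc34)sc2c1` differs from compound 1 only in hydrogen in place of chloro on an aromatic carbon, so that 2-chlorobenzyl becomes benzyl. For the measured compounds named here, the only measured step touching that benzyl position is a 1.3-fold lower number from compound 2 to compound 3 (0.11 log units; within the scatter), which removed the whole 2,4-dichlorobenzyl with little effect. Dropping a single chloro is therefore expected to move this assay little, if at all, as a 1.3-fold higher number from compound 1 to compound 4 (0.10 log units; within the scatter). Compound 4 is estimated at 1500 nM, within 700 nM to 3200 nM.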

Compound 4, half-maximal inhibitory concentration: 1340 nM
Estimate against measurement, compound 4: 1.1-fold (0.05 log units) above; the measured number falls inside the stated range.
By their numbers in this assay, from the lowest: compounds 1, 4, 3 and 2 (each within the scatter of the next, the first and the last beyond it).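

Taking the chloro off the 2-chlorobenzyl group gives a 1.1-fold higher number from compound 1 to compound 4 (0.06 log units; within the scatter) in this assay, so the two compounds cannot be told apart in this assay. The earlier step at this position exchanged the whole 2,4-dichlorobenzyl for hydrogen, whereas this one changes a single atom with the dimethylaminomethyl arm kept in place, and the number still holds level. No measurement shown here accounts for this result.

Going by these compounds, it remains open whether a larger group on this ring, such as methoxy or trifluoromethyl, would leave the number just as level.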